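The compounds below may be only part of what the source reports. "The series", "measured", "known", "first", "only" and "open" are said of these compounds alone.

In a functional assay on SV5A8 cells (Homo sapiens) for cytotoxicity (on this read-out lower numbers stand for stronger inhibition and higher numbers for weaker inhibition), compound 3 `Cc1ccc2c(NCc3ccc(NC(=O)C4CCN(Cc5ccco5)CC4)cc3)nc(N(C)C)nc2c1` reaches only a limit, > 20000 nM. Compound 1 `Cc1ccc2c(NCc3ccc(NC(=O)C4CCN(Cc5ccc(Cl)cc5)CC4)cc3)nc(N(C)C)nc2c1` likewise reaches only a limit in this assay, > 3180 nM. Compound 2 `Cc1ccc2c(NCc3ccc(NC(=O)C4CCN(Cc5ccc(F)cc5Cl)CC4)cc3)nc(N(C)C)nc2c1` also reaches only a limit in this assay, > 5910 nM. Every value shown is a limit. The steps a step that the two limits leave unreadable from compound 1 to compound 2, a step that the two limits leave unreadable from compound 1 to compound 3 and a step that the two limits leave unreadable from compound 2 to compound 3 cannot be read for size or direction. Compound 4 `Cc1ccc2c(NCc3ccc(NC(=O)C4CCN(C5CCCCC5)CC4)cc3)nc(N(C)C)nc2c1` differs from compound 3 by cyclohexyl in place of (furan-2-yl)methyl on an amine nitrogen in a ring. Among the compounds with values here, no measured step offers a readable size, so no change beyond the scatter can be predicted in this assay in either direction. Compound 4 is therefore expected to sit near the same limit, with an estimated value of 20000 nM between 5000 nM and 60000 nM. The expected step is a number no higher from compound 3 to compound 4 (the limit leaves the size open).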

Compound 4, half-maximal inhibitory concentration: > 8320 nM
Compound 4: no number, only a limit; the forecaster's own chance of this, stated with the estimate: 80%; the middle value lies beyond the limit too.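

Within the data shown here, compound 4 gives only a limit in this assay, as do compound 1, compound 2 and compound 3, so no step among them can be read. Going by these compounds, whether changing the group on the amine nitrogen in a ring alters the read-out at all stays open.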